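The source may report more compounds than this note shows. Statements on the series, on what has been measured and on what is new or still open speak of the compounds shown alone.

Compound 1 `Nc1ccccc1NC(=O)c1ccc(CSC(=S)N2CCN(c3ccc(Cl)cc3)CC2)cc1`: 44.8%
Compound 2 `COc1ccc(N2CCN(C(=S)SCc3ccc(C(=O)Nc4ccccc4N)cc3)CC2)cc1`: 52.3%

Both were measured in a functional assay on HeLa cells (Homo sapiens) for antiproliferative activity, read by CCK-8 assay, with a stated time of 72 h, tested at 8 uM; a lower number here means a weaker effect, a higher number a stronger effect of the compound at the concentration tested. Compound 2 gives the higher of the two numbers, but its nearest neighbour, compound 1, lies only a number 7.5 percentage points higher from compound 1 to compound 2 (within the scatter), so the two cannot be told apart. Compound 3 `Nc1ccccc1NC(=O)c1ccc(CSC(=S)N2CCN(Cc3ccncc3)CC2)cc1` brings a different change: (pyridin-4-yl)methyl in place of 4-methoxyphenyl on an amine nitrogen in a ring. Among the compounds with values here, the only measured step, a number 7.5 percentage points higher from compound 1 to compound 2 (within the scatter), exchanged a small group on an aromatic carbon, so it bears only loosely on this larger swap of the whole ring. Within the data shown here, with no closer precedent, no shift beyond the scatter is expected. Compound 3 is estimated at 46%, between 26% and 66%, meaning an expected step of a number 6.3 percentage points lower from compound 2 to compound 3 (within the scatter).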

Compound 3, a percentage reported as inhibition, at one concentration (the size of the read-out at that concentration, not a potency): 72.9%
The estimate for compound 3 lay 26.9 percentage points below the measured number, and the stated range ends below it.
By their numbers in this assay, from the lowest: compounds 1 and 2 (each within the scatter of the next); then compound 3.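

In this assay, (pyridin-4-yl)methyl in place of 4-methoxyphenyl gives a number 20.6 percentage points higher from compound 2 to compound 3 (beyond the scatter), and in place of 4-chlorophenyl it gives a number 28.1 percentage points higher from compound 1 to compound 3 (beyond the scatter). This amine nitrogen in the ring therefore tolerates a swap of the whole group and responds to it beyond the scatter, something the exchange of a small group on the aromatic ring did not show. Nothing measured here explains the rise. From the compounds shown here alone, it remains open whether the ring nitrogen of the pyridine or the methyl link matters more. A benzyl group or a directly attached pyridin-4-yl would separate the two.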